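Hydrogen in Place of Methoxy on Compound 2

The source may report more compounds than this note shows. Statements on the series, on what has been measured and on what is new or still open speak of the compounds shown alone.

Measured so far in a functional assay on LoVo cells (Homo sapiens) for cytotoxicity, read by MTT assay, with a stated time of 72 h; a higher number here means a weaker inhibitor, a lower number a stronger inhibitor
- Compound 1 `Cc1ccc2[nH]c(-n3cccn3)c(C3=C(Br)C(=O)NC3=O)c2c1` gives 27000 nM
- Compound 2 `COc1ccc2[nH]c3c4cn[nH]c4c4c(c3c2c1)C(=O)NC4=O` gives 42000 nM
- Compound 3 `O=C1NC(=O)c2c1c1c3cc(O)ccc3[nH]c1c1cccn21` gives 99000 nM

Compound 2 at 42000 nM cannot be told apart from compound 1 at 27000 nM, since their gap lies within the usual scatter of repeated measurements. Compound 3 at 99000 nM stands higher than compound 2, by a gap beyond that scatter. Compound 4 `O=C1NC(=O)c2c1c1[nH]ncc1c1[nH]c3ccccc3c21` has hydrogen in place of methoxy on an aromatic carbon. Among the measured compounds shown here, no measured pair shows this change alone, so its size is unknown. A step within the scatter is expected in this assay, with no firm direction. The estimated change is a 1.1-fold lower number from compound 2 to compound 4 (0.04 log units; within the scatter). For compound 4 the estimated value is 38000 nM, with an expected range from 13000 nM to 100000 nM.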

Compound 4, half-maximal inhibitory concentration: 44000 nM
The estimate for compound 4 lay 1.2-fold (0.06 log units) below the measured number; the measured number falls inside the stated range.
By their numbers in this assay, from the lowest: compounds 1, 2 and 4 (each within the scatter of the next); then compound 3.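

In this assay, the first pair differing only at this position gives a 1.0-fold higher number from compound 2 to compound 4 (0.02 log units; within the scatter) for hydrogen in place of methoxy on the aromatic carbon. Compounds 2 and 4 therefore cannot be told apart, so in this pair the methoxy is not needed for activity at this level. Nothing measured here offers an explanation for this result.

On these data alone, it remains open whether a different group at this position, such as an amine or a carboxylic acid, would give a number clearly apart from those of compound 2 and compound 4.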